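The source may report more compounds than this note shows. Statements on the series, on what has been measured and on what is new or still open speak of the compounds shown alone.

Within the data shown here, compound 1 `CN(Cc1ccccc1)S(=O)(=O)c1ccc(NC(=O)NCc2ccncc2)cc1` holds the only number given in an assay on isolated protein for activation of Nicotinamide phosphoribosyltransferase (Homo sapiens) (a higher number here means that more compound is needed for the effect, a lower number that less compound is needed), where compound 1 gives 23 nM as its half-maximal effective concentration. Compound 2 `CCOC(=O)c1ccc(NC(=O)N(C)Cc2ccncc2)cc1` reaches only a limit of this assay and gives > 100000 nM rather than a number, as the limit of > 100000 nM in this assay, at which 1 of the 2 values shown sits, records. Compound 3 `O=C(NCc1ccncc1)Nc1ccc(S(=O)(=O)c2ccc(Cl)cc2)cc1` has not been measured; it differs from compound 1 by 4-chlorophenyl in place of benzyl(methyl)amino on a sulfonyl sulfur. Among the measured compounds shown here, no measured step between related compounds is available to lean on, so the expected step from compound 1 to compound 3 is modest, within or only slightly beyond the usual scatter, namely a 2.6-fold higher number from compound 1 to compound 3 (0.42 log units; beyond the scatter). Compound 3 is therefore expected to give 60 nM, with a range from 10 nM to 500 nM in this assay.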

Compound 3, half-maximal effective concentration: 126 nM
Compound 3: middle estimate off by 2.1-fold (0.32 log units), on the low side; the measured number falls inside the stated range.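

At this place on the sulfonyl sulfur, 4-chlorophenyl can replace benzyl(methyl)amino and compound 3 still gives a measurable number in this assay, with a cost of a 5.5-fold higher number from compound 1 to compound 3 (0.74 log units; beyond the scatter). The nitrogen of benzyl(methyl)amino is therefore not needed for a measurable number, although the change is not neutral. Nothing shown here accounts for the size of this step.

The compounds shown leave open whether a dimethylamino group or a plain phenyl on the sulfonyl sulfur would come closer to compound 1. They also leave open what the chlorine contributes to compound 3.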